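Acetamide to propanamide on a benzyloxy melatonin analogue

The source may report more compounds than this note shows. Statements on the series, on what has been measured and on what is new or still open speak of the compounds shown alone.

Measured so far:
compound 1 `COc1ccc(O)c(CCCNC(C)=O)c1` — 46.2 nM
compound 2 `COc1cc(COc2ccc(OC)cc2CCCNC(C)=O)cc(OC)c1` — 0.0326 nM
compound 3 `COc1cc(CCCNC(C)=O)ccc1OCc1ccccc1` — 69.3 nM

In an assay on CHO cells for displacement of a labelled ligand from melatonin receptor type 1B (Homo sapiens), read by scintillation counting, with a stated time of 60 min (a higher number here means a weaker inhibitor, a lower number a stronger inhibitor), compound 3 gives the highest of the three numbers. Compound 1 sits close by, within the scatter of this assay, whereas compound 2 lies far lower, well beyond it. Compound 4 `CCC(=O)NCCCc1ccc(OCc2ccccc2)c(OC)c1` differs from compound 3 in one place: methyl in place of hydrogen on a saturated chain carbon bound to a carbonyl carbon. For the measured compounds named here, no step of this kind between measured compounds is available here, so the size of its effect in this assay is not known from the data. Compound 4 is expected to give a number close to that of compound 3, with the step of a 1.4-fold lower number from compound 3 to compound 4 (0.14 log units; within the scatter) expected to stay within the scatter. The estimate for compound 4 is 50 nM, in a range from 15 nM to 160 nM.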

Compound 4, inhibition constant: 121 nM
For compound 4 the middle estimate is 2.4-fold (0.38 log units) below the measured one; the measured number falls inside the stated range.
By their numbers in this assay, from the lowest: compound 2; then compounds 1, 3 and 4 (each within the scatter of the next, the first and the last beyond it).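

Acetamido to propanoylamino, with methyl in place of hydrogen on a saturated chain carbon bound to a carbonyl carbon, gives in this assay a 1.7-fold higher number from compound 3 to compound 4 (0.24 log units; within the scatter) and so leaves the two compounds indistinguishable. For the compounds shown here, this is the first one-place step at this position, and it shows that this one added methyl is tolerated there without a change beyond the scatter. No supporting measurement bears on this result.

From the compounds shown here alone, whether a longer chain such as butanoyl, a cyclopropyl ring or an amine would be tolerated at this position remains open. So does whether the same methyl step would behave alike on compound 2.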